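Branching the Linker on a Bombesin Receptor Subtype-3 Agonist

The source may hold more compounds than are shown below. What is called first, only, known or untested is meant among the compounds shown, and "the series" means these compounds.

The measured compounds:
Compound 1 `CCCCc1cnc(Cc2ccc(-c3ccccc3C(=O)O)cc2)[nH]1`: in an in vitro functional assay on cells for agonist activity at Bombesin receptor subtype-3 (Homo sapiens), read by luminescence and calcium flux (a lower number here means that less compound is needed, a higher number that more compound is needed for the effect), compound 1 gives only a limit, > 10000 nM.
Compound 2 `CCCCc1cnc(C(C)Cc2ccc(-c3ccccc3C(=O)O)cc2)[nH]1`: in this assay compound 2 gives 2760 nM.
Compound 3 `O=C(O)c1ccccc1-c1ccc(CCc2ncc(CC3CCOCC3)[nH]2)cc1`: in this assay compound 3 gives 338 nM.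

Compound 2 stands highest of the two numbers; compound 3 sits lower, beyond the usual scatter. Compound 1 sits at the assay's limit (the limit of > 10000 nM in this assay, at which 1 of the 3 values shown sits), so its gap to compound 2 cannot be sized.

Compound 4 `CCCCc1cnc(C(CCCC)Cc2ccc(-c3ccccc3C(=O)O)cc2)[nH]1` differs from compound 2 by propyl in place of hydrogen on a saturated chain carbon, two bonds along the chain from an aromatic carbon. No step of this kind has been measured among these compounds. Compound 1 carries hydrogen where compound 2 carries methyl, and their two values show compound 2 with a number and compound 1 with only a limit; from that alone no size for a further lengthening can be read. Compound 4 is expected to give 1500 nM, within 400 nM to 6000 nM. That estimate means a step of a 1.8-fold lower number from compound 2 to compound 4 (0.26 log units; within the scatter), expected to be small and possibly within the scatter.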

Compound 4, half-maximal effective concentration: 2660 nM
The estimate for compound 4 lay 1.8-fold (0.25 log units) below the measured number; low and high end bracket the measured number.
By their numbers in this assay, from the lowest: compound 3; then compounds 4 and 2 (each within the scatter of the next). At a limit, above all of these: compound 1.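

In this assay, the methyl to butyl difference on the saturated chain carbon, two bonds along the chain from an aromatic carbon, amounts to a 1.0-fold lower number from compound 2 to compound 4 (0.02 log units; within the scatter). At this position, then, a chain much longer than methyl still gives a measured number, and the two chains cannot be told apart in this assay. Compound 1, which carries hydrogen on this carbon, gives only a limit and not a number: the limit of > 10000 nM in this assay, at which 1 of the 4 values shown sits.

The compounds shown leave open whether a chain of intermediate length, such as ethyl, would read the same, and whether an amine or a carboxylic acid on this carbon would shift the number. They also leave open whether a butyl group here would read alike on the core of compound 3.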